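Thiazole series on HT-29: aryl swap and amine-to-methyl step

A few compounds are considered here, and "the series" means these few. Any claim that something is new, unique, unknown or untested is made for them only; others in the source may bear on it.

Compound 1 `COc1cc(-c2nc(N(C)C)sc2-c2ccc3ccccc3c2)cc(OC)c1OC` gives 729 nM in a functional assay on HT-29 cells (Homo sapiens) for antiproliferative activity, read by MTT assay, with a stated time of 72 h; on this read-out lower numbers stand for stronger inhibition and higher numbers for weaker inhibition. Compound 2 `COc1cc(-c2nc(N(C)C)sc2-c2ccc(C)cc2)cc(OC)c1OC` gives 3920 nM in this assay; the cores of compounds 1 and 2 differ by 4-methylphenyl in place of naphthalen-2-yl on an aromatic carbon, and the step is a 5.4-fold higher number from compound 1 to compound 2 (0.73 log units; beyond the scatter). Compound 3 `COc1cc(-c2nc(C)sc2-c2ccc3ccccc3c2)cc(OC)c1OC` gives 702 nM in this assay, with the change methyl in place of dimethylamino on an aromatic carbon giving a 1.0-fold lower number from compound 1 to compound 3 (0.02 log units; within the scatter). Compound 4 `COc1cc(-c2nc(C)sc2-c2ccc(C)cc2)cc(OC)c1OC` is not yet measured. It differs from compound 2 by methyl in place of dimethylamino on an aromatic carbon, the same kind of change as from compound 1 to compound 3, though around the place one ring atom bears a 4-methylphenyl group rather than a naphthalen-2-yl group. Compound 4 is expected to sit near compound 2 in this assay, with a step of about a 1.0-fold lower number from compound 2 to compound 4 (0.00 log units; within the scatter), because the matching change gave a 1.0-fold lower number from compound 1 to compound 3 (0.02 log units; within the scatter). The estimate for compound 4 is 3900 nM, between 1800 nM and 8500 nM.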

Compound 4, half-maximal inhibitory concentration: 722 nM
For compound 4 the middle estimate is 5.4-fold (0.73 log units) above the measured one, outside the stated range (below it).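

In this assay, methyl in place of dimethylamino gives a 5.4-fold lower number from compound 2 to compound 4 (0.73 log units; beyond the scatter). The change therefore does not carry over at a constant size between the core bearing naphthalen-2-yl and the core bearing 4-methylphenyl: the same change on two cores in this assay, a 1.0-fold lower number (0.02 log units; within the scatter) from compound 1 to compound 3 and a 5.4-fold lower number (0.73 log units; beyond the scatter) from compound 2 to compound 4, 5.2-fold (0.72 log units) apart, beyond the scatter of two such steps. These two pairs show that the size of this step can differ with the group on the shared core, but they give no rule for any other core and no reason for the gap.

Still open, on these data alone, is how the step behaves with a plain phenyl or a 4-methoxyphenyl group in place of 4-methylphenyl. Also open, as far as these compounds go, is whether a primary amine or a longer chain such as propyl, in place of methyl, follows either pair.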